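The compounds below may be only part of what the source reports. "The series", "measured", "known", "first", "only" and "open" are said of these compounds alone.

Measured in a functional assay on MDA-MB-231 cells (Homo sapiens) for inhibition, read by MTT assay, with a stated time of 48 h; on this read-out higher numbers stand for weaker inhibition and lower numbers for stronger inhibition:
- compound 1 `O=C(CCCCNC(=O)Cn1cnc2c(Nc3ccccc3)nc(Nc3ccccc3)nc21)NO`: 11100 nM
- compound 2 `O=C(CCCCCNC(=O)Cn1cnc2c(Nc3ccccc3)nc(Nc3ccccc3)nc21)NO`: 1610 nM
- compound 3 `O=C(CCCCCCNC(=O)Cn1cnc2c(Nc3ccccc3)ncnc21)NO`: 8910 nM

Compound 3 holds the second highest of the three numbers, within the scatter of compound 1 and beyond the scatter above compound 2. The step to compound 4 `O=C(CCCCCCNC(=O)Cn1cnc2c(Nc3ccccc3)nc(Nc3ccccc3)nc21)NO` is anilino in place of hydrogen on an aromatic carbon. Within the data shown here, no measured step isolates this change. The only one, a 6.9-fold lower number from compound 1 to compound 2 (0.84 log units; beyond the scatter), is modest and lies in the chain. Compound 2, which carries anilino at that place, gives 1610 nM, whereas compound 1, which also carries it, gives 11100 nM. A modest drop is therefore expected, though with wide uncertainty. The expected step is a 4.5-fold lower number from compound 3 to compound 4 (0.65 log units; beyond the scatter). Compound 4 is estimated at 2000 nM, with an expected range of 600 nM to 6500 nM.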

Compound 4, half-maximal inhibitory concentration: 1550 nM
Estimate against measurement, compound 4: 1.3-fold (0.11 log units) above, and the stated range covers the measured number.
By their numbers in this assay, from the lowest: compounds 4 and 2 (each within the scatter of the next); then compounds 3 and 1 (each within the scatter of the next).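

In this assay, anilino in place of hydrogen on the aromatic carbon between two ring nitrogen atoms now has a step of its own with the chain unchanged (a 5.7-fold lower number from compound 3 to compound 4 (0.76 log units; beyond the scatter)). Along the chain, (hydroxycarbamoyl)methyl in place of hydroxycarbamoyl stays within the scatter (a 1.0-fold lower number from compound 2 to compound 4 (0.02 log units; within the scatter)), while 2-(hydroxycarbamoyl)ethyl in place of hydroxycarbamoyl goes beyond it (a 7.2-fold lower number from compound 1 to compound 4 (0.85 log units; beyond the scatter)), so the drop from the shortest chain does not continue past compound 2. Nothing available explains either step. Going by these compounds, it remains open whether a morpholine at this place would serve as anilino does, and whether a longer chain than that of compound 4 would hold the number.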